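From acetyl to aminocarbamoyl on the shared core

The source may report more compounds than this note shows. Statements on the series, on what has been measured and on what is new or still open speak of the compounds shown alone.

Measured in a functional assay on cells (Lymphocyte, Homo sapiens) for cytotoxicity; a lower number here means that less compound is tolerated, a higher number that more compound is tolerated:
compound 1 `CNNC(=O)c1[nH]c2ccc(Cl)cc2c1S(=O)(=O)c1cc(C)cc(C)c1` gives > 100 uM
compound 2 `CC(=O)NNC(=O)c1[nH]c2ccc(Cl)cc2c1S(=O)(=O)c1cc(C)cc(C)c1` gives > 100 uM

Compound 2 stands at > 100 uM, which is a limit of the assay and not a number. Compound 1 stands at > 100 uM, also a limit. Among the measured compounds shown here, the series so far comes down to one entry: the limit of > 100 uM in this assay, at which 2 of the 2 values shown sit.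

Compound 3 `Cc1cc(C)cc(S(=O)(=O)c2c(C(=O)NNC(=O)NN)[nH]c3ccc(Cl)cc23)c1` differs from compound 2 by aminoamino in place of methyl on a carbonyl carbon. Cut one bond further out, the same difference reads acetyl to aminocarbamoyl.

For the measured compounds named here, the only measured step bearing on this change is a step that the two limits leave unreadable from compound 1 to compound 2, so no measured size can be carried over. No step beyond the usual scatter is therefore expected in this assay, in either direction. This expectation rests on compound 2 alone, with its limit of > 100 uM. The expected step is a number no higher from compound 2 to compound 3 (the limit leaves the size open). The estimate for compound 3 is 100 uM, with an expected range from 40 uM to 200 uM.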

Compound 3, half-maximal toxic concentration: > 100 uM
Compound 3: a limit, no number; the forecaster's own chance of this, stated with the estimate: 75%; the middle value lies on the limit itself.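

Among the compounds shown here, compound 3 gives > 100 uM in this assay, a limit and not a number, and no step among compound 1, compound 2 and compound 3 can be read. Left open is how these three compounds order in this assay, and whether any change on the shared core gives a readable number: the limit of > 100 uM in this assay, at which 3 of the 3 values shown sit.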